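The compounds below may be only part of what the source reports. "The series", "measured", "known", "first", "only" and "open" are said of these compounds alone.

Measured in a functional assay on SK-BR-3 cells (Homo sapiens) for inhibition, read by CellTiter-Glo, with a stated time of 72 h; a higher number here means a weaker inhibitor, a lower number a stronger inhibitor:
- compound 1 `CNc1cc(C(N)=O)ccc1-n1nc(C(C)C)c2c(-n3cnc(-c4cnn(C)c4)c3)ccnc21`: 419 nM
- compound 2 `CC(C)c1nn(-c2ccc(C(N)=O)c(N[C@H]3CC[C@H](O)CC3)c2)c2nccc(-n3cnc(-c4cncnc4)c3)c12`: 387 nM
- compound 3 `COc1ccc(-c2cn(-c3ccnc4c3c(C(C)C)nn4-c3ccc(C(N)=O)c(N[C@H]4CC[C@H](O)CC4)c3)cn2)cc1`: 256 nM

Compound 2, at 387 nM, stands within the scatter of both compound 1 and compound 3, so these three values do not separate it from its neighbours.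

Next in the series is compound 4 `CC(C)c1nn(-c2ccc(C(N)=O)c(N[C@H]3CC[C@H](O)CC3)c2)c2nccc(-c3ccsc3)c12`, which carries thiophen-3-yl in place of 4-(pyrimidin-5-yl)-1H-imidazol-1-yl on an aromatic carbon.

Among the compounds with values here, only one measured step touches this place. That step, a 1.5-fold lower number from compound 2 to compound 3 (0.18 log units; within the scatter), exchanges pyrimidin-5-yl for 4-methoxyphenyl and keeps the imidazolyl part, so it covers only part of the present change. Within the data shown here, no measured compound lacks the imidazolyl part, so the data give only weak guidance here, and the range must stay wide.

Among the measured compounds shown here, with that small step as the sole guide, no shift beyond the scatter is expected in this assay, with a slight lean towards a higher number. The expected change is a 1.4-fold higher number from compound 2 to compound 4 (0.15 log units; within the scatter).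

For compound 4 the estimated value is 550 nM, with an expected range of 130 nM to 2200 nM.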

Compound 4, half-maximal inhibitory concentration: > 10000 nM
Compound 4 was reported as a limit (the forecaster's own chance of this, stated with the estimate: 3%); middle value at least 18-fold (1.25 log units) away from the limit.
By their numbers in this assay, from the lowest: compounds 3, 2 and 1 (each within the scatter of the next). At a limit, above all of these: compound 4.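

In this assay, thiophen-3-yl in place of 4-(pyrimidin-5-yl)-1H-imidazol-1-yl gives an at least 25-fold higher number from compound 2 to compound 4 (1.41 log units; beyond the scatter), so the group on this aromatic carbon, opposite the ring nitrogen, has a large bearing on the read-out. Compound 4 is reported only as a limit of the assay, not as a number: the limit of > 10000 nM in this assay, at which 1 of the 4 values shown sits. The earlier exchange on the outer ring, a 1.5-fold lower number from compound 2 to compound 3 (0.18 log units; within the scatter), kept the imidazolyl part and stayed within the scatter, whereas this change replaces the whole substituent and goes beyond it.

Two rings leave together in this one step, so the compounds shown do not separate the share of the imidazolyl part from that of the pyrimidin-5-yl ring. Also open, going by these compounds, is how a bare 1H-imidazol-1-yl, or an amine such as morpholine, would read at this place.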